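The source may report more compounds than this note shows. Statements on the series, on what has been measured and on what is new or still open speak of the compounds shown alone.

Measured in a functional assay on DU-145 cells (Homo sapiens) for inhibition, read by trypan blue exclusion, with a stated time of 72 h; on this read-out higher numbers stand for weaker inhibition and lower numbers for stronger inhibition:
- Compound 1 (`COc1ccc(Nc2ncc3cc(S(=O)(=O)c4ccc(C)cc4)c(=O)n(C)c3n2)cc1`): 100000 nM
- Compound 2 (`COc1ccc(Nc2ncc3cc(S(=O)(=O)c4ccc(Cl)cc4)c(=O)n(C)c3n2)cc1`): 30000 nM
- Compound 3 (`Cn1ccc2cc(Nc3ncc4cc(S(=O)(=O)c5ccc(F)cc5F)c(=O)n(C)c4n3)ccc21`): 750 nM

Compound 1 stands highest of the three, making it the weakest inhibitor here. Compound 4 (`Cc1ccc(S(=O)(=O)c2cc3cnc(Nc4ccc5ncccc5c4)nc3n(C)c2=O)cc1`) keeps the core of compound 1 and exchanges one group: quinolin-6-yl in place of 4-methoxyphenyl on a nitrogen on an aromatic ring. Among the measured compounds shown here, the only measured step, a 3.3-fold lower number from compound 1 to compound 2 (0.52 log units; beyond the scatter), is modest and concerns a different place, so it bears little on this change. For the measured compounds named here, no measured step isolates quinolin-6-yl in place of 4-methoxyphenyl. Compound 3, at 750 nM, lacks 4-methoxyphenyl but also differs elsewhere, so it only hints that a lower number is possible. A step larger than the measured one is therefore expected in this assay, towards stronger inhibition. The expected step is a 10-fold lower number from compound 1 to compound 4 (1.00 log units; beyond the scatter). For compound 4 the estimated value is 10000 nM, with an expected range from 1500 nM to 60000 nM.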

Compound 4, half-maximal inhibitory concentration: 10000 nM
Compound 4: the middle estimate sits on the measured number at the digits printed; low and high end bracket the measured number.
By their numbers in this assay, from the lowest: compound 3; then compound 4; then compound 2; then compound 1.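

In this assay, quinolin-6-yl in place of 4-methoxyphenyl on this nitrogen gives a 10-fold lower number from compound 1 to compound 4 (1.00 log units; beyond the scatter), the first single change measured at this position. That step is larger than the one for chloro in place of methyl, a 3.3-fold lower number from compound 1 to compound 2 (0.52 log units; beyond the scatter), made at a different place. Nothing at hand accounts for the lower number with quinolin-6-yl.

From the compounds shown here alone, whether the same exchange holds with the chloro group of compound 2 in place remains open. So does how a piperazinylphenyl group would fare on this nitrogen.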